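Opening the Oxolane Ring: From Compound 2 to Compound 3

A few compounds are considered here, and "the series" means these few. Any claim that something is new, unique, unknown or untested is made for them only; others in the source may bear on it.

Compound 1: `COCCn1cc(C(=O)C(=O)Nc2ccc(OC(F)(F)F)cc2)c2ccccc21` — 487 nM
Compound 2: `COc1ccc(NC(=O)C(=O)c2cn(CC3CCCO3)c3ccccc23)cn1` — 31 nM

Of the compounds shown here, two have been measured in a functional assay on FaDu cells (Homo sapiens) for cytotoxicity, read by MTT assay, with a stated time of 72 h; a lower number here means that less compound is tolerated, a higher number that more compound is tolerated. Compound 1 gives 487 nM in this assay, while compound 2 gives 31 nM. Compound 2 therefore holds the lower of the two numbers, and the gap to compound 1 lies beyond the usual scatter, so compound 2 is the less tolerated of the pair by a clear margin.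

Compound 3 is `COc1ccc(NC(=O)C(=O)c2cn(CCOC(C)C)c3ccccc23)cn1`, not yet measured in this assay. It differs from compound 2 in one place: isopropoxymethyl in place of oxolan-2-yl on a saturated chain carbon bound to an aromatic nitrogen. The group that leaves and the group that enters match each other in heavy-atom count and in hydrogen-bond acceptor count; the only difference is that the ring is gone.

Among the measured compounds shown here, with no measured pair of this kind to lean on, a small step is expected in this assay from compound 2 to compound 3, in the direction of a somewhat higher number, of a size that may well fall within the scatter: a 1.6-fold higher number from compound 2 to compound 3 (0.21 log units; within the scatter). Compound 3 is expected to give 50 nM in this assay, within a range of 15 nM to 160 nM.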

Compound 3, concentration lethal to 50% of the cells: 211 nM
For compound 3 the middle estimate is 4.2-fold (0.63 log units) below the measured one, and the stated range ends below it.
By their numbers in this assay, from the lowest: compound 2; then compound 3; then compound 1.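

In this assay, opening the ring did not prove a neutral exchange: a 6.8-fold higher number from compound 2 to compound 3 (0.83 log units; beyond the scatter), a step beyond the scatter, even though the oxolan-2-yl that leaves and the isopropoxymethyl that enters match in heavy-atom count and in hydrogen-bond acceptor count. On a saturated chain carbon bound to an aromatic nitrogen, this assay therefore separates two groups that share these counts, and the ring is the one counted feature that differs between them. No measurement at hand bears on why the number moves in this way.

The compounds shown leave open how a larger saturated ring such as oxan-2-yl, or an amine such as morpholine carried on the same chain, would read at this place on the core of compound 2. They also leave open whether the same exchange of oxolan-2-yl for isopropoxymethyl would give a step of similar size with the trifluoromethoxy-bearing amide part of compound 1.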